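Working notes on compounds 1 to 4

The source may hold more compounds than are shown below. What is called first, only, known or untested is meant among the compounds shown, and "the series" means these compounds.

Measured so far in a functional assay on the whole organism for inhibition, with Rattus norvegicus as the target, read by paw edema, with stated times of 1 h and 3 h; on this read-out higher numbers stand for an effect only at larger amounts of compound and lower numbers for an effect already at smaller amounts:
compound 1 `C/C(=N\OCC(=O)O)c1ccc(Cl)c(Cl)c1`, compound 1 gives 65 mg/kg
compound 2 `C/C(=N\OCCC(=O)O)c1ccc(Cl)cc1`, compound 2 gives 80 mg/kg
compound 3 `C/C(=N\OC(C)C(=O)O)c1ccc(Cl)cc1`, compound 3 gives 55 mg/kg

Compound 2 holds the highest of the three numbers, but its gaps to compound 1 and compound 3 both fall within the scatter, so the three compounds cannot be ordered. Within the data shown here, the only measured single-point step is a 1.5-fold lower number from compound 2 to compound 3 (0.16 log units; within the scatter), which rearranges the chain but keeps the carboxy.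

Compound 4 `COC(=O)OCCO/N=C(\C)c1ccc(Cl)cc1` differs from compound 2 as follows: (methoxycarbonyl)oxy in place of carboxy on a saturated chain carbon, two bonds along the chain from an oxygen. No measured step removes the carboxy, so nothing shown bears directly on this change, and the expectation rests only on the narrow span of the three values. Compound 4 is therefore estimated near the series at 90 mg/kg, with a wide range from 40 mg/kg to 200 mg/kg. The expected step is a 1.1-fold higher number from compound 2 to compound 4 (0.05 log units; within the scatter), no direction claimed beyond the scatter.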

Compound 4, dose for half-maximal effect: 33 mg/kg
Compound 4: the middle estimate sits 2.7-fold (0.44 log units) above what was measured; the measured number lies below the stated range.
By their numbers in this assay, from the lowest: compounds 4, 3, 1 and 2 (each within the scatter of the next, the first and the last beyond it).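

In this assay, among these compounds, the change to (methoxycarbonyl)oxy gives a 2.4-fold lower number from compound 2 to compound 4 (0.38 log units; beyond the scatter) and is the first measured step to lie beyond the scatter. The effect at this place on the chain therefore does not depend on the carboxy, and it persists with the hydrogen-bond donor count going from 1 to 0. No measurement shown explains this shift.

As far as these compounds go, it remains open whether the step follows from losing the carboxy or from the entering group itself. A hydroxy group or a methyl ester at the same place would separate these two readings.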